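Adding a third methoxy group to the lactam analogue

This account rests on a few compounds, and the source may have more. Where it says the series, first, only, none or still open, it means among the compounds named here.

The two measured compounds share a styryl-linked core and differ in both the ring at the end of the chain and the aromatic substitution. Compound 1 `COc1cc(/C=C/C2CC(=O)C=CO2)cc(OC)c1OC` gives 127 uM in a functional assay on NCI-H460 cells (Homo sapiens) for inhibition, read by sulforhodamine B assay, with a stated time of 48 h; a lower number here means a stronger inhibitor of growth, a higher number a weaker inhibitor of growth. Compound 2 `COc1cc(/C=C/C2CC=CC(=O)N2)cc(OC)c1` gives 146 uM in the same this assay and carries the highest number of the two, though its gap to compound 1 lies within the scatter, so neither can be called the weaker inhibitor of growth. Compound 3 `COc1cc(/C=C/C2CC=CC(=O)N2)cc(OC)c1OC` differs from compound 2 by one change, (methoxy in place of hydrogen on an aromatic carbon). Going by the values given here, no measured pair shows the effect of this change alone. Since compound 1 already holds the third methoxy group and gives 127 uM, the step is expected to be small, a 1.2-fold lower number from compound 2 to compound 3 (0.09 log units; within the scatter), with no direction beyond the scatter. Compound 3 is therefore estimated at 120 uM, within a range from 50 uM to 300 uM.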

Compound 3, concentration for growth inhibition (reported as GI): > 864 uM
Compound 3: only a limit was reported (the forecaster's own chance of this, stated with the estimate: 10%); middle value at least 7.2-fold (0.85 log units) away from the limit.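

The reading for compound 3 in this assay is a limit and not a number: the limit of > 864 uM in this assay, at which 1 of the 3 values shown sits. Even so, methoxy in place of hydrogen on this aromatic carbon, ortho to two methoxy groups and para to a group of 9 heavy atoms, is the first single change here to move growth inhibition beyond the scatter, giving an at least 5.9-fold higher number from compound 2 to compound 3 (0.77 log units; beyond the scatter). With the same three methoxy groups on the aromatic ring, exchanging the end group of the chain gives an at least 6.8-fold higher number from compound 1 to compound 3 (0.83 log units; beyond the scatter), so the effect of the third methoxy group depends on the group at the end of the chain.

As far as these compounds go, whether a hydroxyl, a chlorine or an amine on that aromatic carbon would behave as methoxy does stays open. From the compounds shown here alone, the true size of both steps also remains unknown, as only a limit is available for compound 3.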